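Methyl for chloro on the pendant phenyl: compound 4

This account rests on a few compounds, and the source may have more. Where it says the series, first, only, none or still open, it means among the compounds named here.

Working notes. In a functional assay on the whole organism (strain albino) for inhibition, with Rattus norvegicus as the target, read by paw edema, with stated times of 1 h and 4 h, at a dose of 200 mg/kg by the oral route (a lower number here means less inhibition, a higher number more inhibition at the dose given (going by the name of the read-out)), compound 1 `O=c1oc2ccccc2cc1C1=NN(c2ccccc2)[C@@H](c2ccccc2)C1` gives 32.7%, compound 2 `O=c1oc2ccccc2cc1C1=NN(c2ccccc2)[C@@H](/C=C/c2ccccc2)C1` gives 42.5%, and compound 3 `O=c1oc2ccccc2cc1C1=NN(c2ccccc2)[C@@H](c2ccc(Cl)cc2)C1` gives 64.7%, the highest of the three numbers: a number 32 percentage points higher from compound 1 to compound 3 (beyond the scatter) and a number 22.2 percentage points higher from compound 2 to compound 3 (beyond the scatter), whereas a number 9.8 percentage points higher from compound 1 to compound 2 (within the scatter). Compound 4 `Cc1ccc([C@H]2CC(c3cc4ccccc4oc3=O)=NN2c2ccccc2)cc1` differs from compound 3 by methyl in place of chloro on an aromatic carbon. Going by the values given here, the only measured step at that aromatic carbon is the one from hydrogen to chloro, a number 32 percentage points higher from compound 1 to compound 3 (beyond the scatter); no step from chloro to methyl, nor from hydrogen to methyl, has been measured, so how much of that gain survives with methyl in place of chloro is open. Part of the gain is expected to be given back, the expected step being a number 14.7 percentage points lower from compound 3 to compound 4 (beyond the scatter). Compound 4 is therefore estimated at 50%, within 35% to 65%.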

Compound 4, a percentage reported as inhibition, in the whole organism at one dose (the size of the read-out at that dose, not a potency): 38%
Compound 4: the middle estimate sits 12 percentage points above what was measured; the range from low to high includes it.
By their numbers in this assay, from the lowest: compounds 1, 4 and 2 (each within the scatter of the next); then compound 3.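

In this assay, at the aromatic carbon para to a large group, 4-methylphenyl for 4-chlorophenyl gives a number 26.7 percentage points lower from compound 3 to compound 4 (beyond the scatter), while methyl in place of hydrogen at that carbon gives a number 5.3 percentage points higher from compound 1 to compound 4 (within the scatter), so the gain seen with chloro does not carry over to methyl. With a number 4.5 percentage points lower from compound 2 to compound 4 (within the scatter) as well, compound 3 alone stands apart among the four. Nothing available explains the difference between chloro and methyl at this carbon.

Open, going by these compounds, is whether fluoro, bromo or methoxy at this carbon would read like chloro or like methyl.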